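The compounds below may be only part of what the source reports. "The series", "measured", "known", "first", "only" and "open" are said of these compounds alone.

Measured so far in a functional assay on HepG2 cells (Homo sapiens) for cytotoxicity, read by MTT assay, with a stated time of 72 h; on this read-out higher numbers stand for weaker inhibition and lower numbers for stronger inhibition:
compound 1 `O=C(N/N=C/c1cccc(Cl)c1Cl)Nc1cc2c(Nc3ccc(F)c(Cl)c3)ncnc2cc1O[C@H]1CCOC1` gives 16900 nM
compound 2 `COc1ccc(/C=N/NC(=O)Nc2cc3c(Nc4ccc(F)c(Cl)c4)ncnc3cc2O[C@H]2CCOC2)cc1` gives 28800 nM
compound 3 `COc1cc2ncnc(Nc3ccc(F)c(Cl)c3)c2cc1NC(=O)N/N=C/c1cccc(Cl)c1Cl` gives 26100 nM

All three numbers sit close together. The change 4-methoxyphenyl in place of 2,3-dichlorophenyl on a carbon with a double bond to nitrogen gave a 1.7-fold higher number from compound 1 to compound 2 (0.23 log units; within the scatter), and the change methyl in place of oxolan-3-yl on an oxygen on an aromatic ring gave a 1.5-fold higher number from compound 1 to compound 3 (0.19 log units; within the scatter); neither step leaves the scatter. Compound 3 and compound 2 differ at two places at once, and their values show no separation either.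

Compound 4 `COc1ccc(/C=N/NC(=O)Nc2cc3c(Nc4ccc(F)c(Cl)c4)ncnc3cc2OC)cc1` has not been measured. It differs from compound 3 by 4-methoxyphenyl in place of 2,3-dichlorophenyl on a carbon with a double bond to nitrogen, the same change that was made from compound 1 to compound 2; the two cores differ by methyl in place of oxolan-3-yl on an oxygen on an aromatic ring. Because the earlier step was a 1.7-fold higher number from compound 1 to compound 2 (0.23 log units; within the scatter), the same change on the core of compound 3 is expected to give a step of about a 1.6-fold higher number from compound 3 to compound 4 (0.21 log units; within the scatter) in this assay, a small movement toward a higher number that may itself lie within the scatter. The estimate for compound 4 in this assay is 42000 nM, with a likely range from 21000 nM to 85000 nM.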

Compound 4, half-maximal inhibitory concentration: 21300 nM
The estimate for compound 4 lay 2.0-fold (0.29 log units) above the measured number; the measured number falls inside the stated range.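

In this assay, 4-methoxyphenyl in place of 2,3-dichlorophenyl gives a 1.2-fold lower number from compound 3 to compound 4 (0.09 log units; within the scatter), and methyl in place of oxolan-3-yl gives a 1.4-fold lower number from compound 2 to compound 4 (0.13 log units; within the scatter), so neither new step leaves the scatter. Carrying the first change from one core to the other shows no measurable difference between the two cores: the same change on two cores in this assay, a 1.7-fold higher number (0.23 log units; within the scatter) from compound 1 to compound 2 and a 1.2-fold lower number (0.09 log units; within the scatter) from compound 3 to compound 4, 2.1-fold (0.32 log units) apart, within the scatter of two such steps

The second change reads the same way, but with every step this small, the series shows only that no dependence on the core is visible, not that either change carries over with a fixed size or direction: the same change on two cores in this assay, a 1.5-fold higher number (0.19 log units; within the scatter) from compound 1 to compound 3 and a 1.4-fold lower number (0.13 log units; within the scatter) from compound 2 to compound 4, 2.1-fold (0.32 log units) apart, within the scatter of two such steps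

The compounds shown leave open whether any change at these two places can move the number beyond the scatter. An amine or a carboxylic acid in place of the methoxy group of the 4-methoxyphenyl, or a longer chain in place of methyl on the oxygen on the aromatic ring, would give steps that might be large enough to compare between cores.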